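The compounds below may be only part of what the source reports. "The series", "measured", "known", "first", "only" and "open" are said of these compounds alone.

Working notes on the series. In an ADME assay on L02 cells (Homo sapiens) for cytotoxicity, read by MTT assay, with a stated time of 24 h (on this read-out higher numbers stand for weaker inhibition and lower numbers for stronger inhibition), compound 1 `CN1C/C(=C\c2cccnc2)C(=O)/C(=C/c2ccccc2C(F)(F)F)C1` gives 14100 nM. Compound 3 `CN1C/C(=C\c2ccncc2)C(=O)/C(=C/c2cc([N+](=O)[O-])ccc2F)C1` gives 17600 nM, which lies within the scatter of the number for compound 1, so the two carry no order. Compound 2 `CN1C/C(=C\c2ccc(C#N)cc2)C(=O)/C(=C/c2cccnc2)C1` reads > 20000 nM, which is a limit of the assay and not a number. Compound 1 therefore has a single numerical neighbour, compound 3, and stands level with it.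

Compound 4 `CN1C/C(=C\c2ccncc2)C(=O)/C(=C/c2ccccc2C(F)(F)F)C1` has the same atoms as compound 1, joined differently: pyridin-4-yl in place of pyridin-3-yl on a double-bonded chain carbon bound to a double-bonded ring carbon, on a double-bonded chain carbon bound to a double-bonded ring carbon. Among the measured compounds shown here, no measured pair differs in one place, so this swap has no direct precedent. Compound 3, which also carries pyridin-4-yl, gives 17600 nM. In this assay, no step beyond the scatter is expected, and the estimated step of a 1.1-fold higher number from compound 1 to compound 4 (0.05 log units; within the scatter) is small. For compound 4 the estimate is 16000 nM, with an expected range of 9000 nM to 26000 nM.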

Compound 4, half-maximal inhibitory concentration: 15800 nM
The estimate for compound 4 lay 1.0-fold (0.01 log units) above the measured number, and the stated range covers the measured number.
By their numbers in this assay, from the lowest: compounds 1, 4 and 3 (each within the scatter of the next). At a limit, above all of these: compound 2.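

Among the compounds shown here, the swap of pyridin-3-yl for pyridin-4-yl on a double-bonded chain carbon bound to a double-bonded ring carbon gives the first one-place step in this assay: a 1.1-fold higher number from compound 1 to compound 4 (0.05 log units; within the scatter). For the compounds shown here, this assay therefore does not separate the two pyridinyl groups in this pair, something the earlier compounds, which differ in more than one place, could not show. The finding rests on one pair, and the upper end of the readable range is a limit of the assay, not a number: the limit of > 20000 nM in this assay, at which 1 of the 4 values shown sits.

Going by these compounds, whether the swap stays this small once the trifluoromethyl-bearing phenyl group is exchanged remains open. Also open, on these data alone, is what a group other than a pyridinyl ring, such as a phenyl carrying a dimethylamino group or a carboxylic acid, would do at this place.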